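A few compounds are considered here, and "the series" means these few. Any claim that something is new, unique, unknown or untested is made for them only; others in the source may bear on it.

Within the data shown here, in an ADME assay on L6 cells (Rattus norvegicus) for cytotoxicity (on this read-out lower numbers stand for stronger inhibition and higher numbers for weaker inhibition), compound 1 `N=C(N)c1ccc(-c2cc3cc(C(=N)N)ccc3o2)cc1` gives 1900 nM, the only number so far. Compound 2 `COc1cc(C(=N)NC(C)C)cc2cc(-c3ccc(C(=N)NC(C)C)cc3)oc12` gives only a limit, > 190000 nM. Compound 3 `N=C(N)c1ccc(-c2cc3cc(C(=N)N)cc(O)c3o2)cc1` differs from compound 1 by a single change, (hydroxy in place of hydrogen on an aromatic carbon), hydroxy in place of hydrogen on an aromatic carbon. Among the measured compounds shown here, no measured step in this assay covers this change, so only a modest move is expected, leaning towards weaker inhibition. The expected step is a 1.8-fold higher number from compound 1 to compound 3 (0.27 log units; within the scatter). Compound 3 is estimated at 3500 nM, with an expected range of 900 nM to 15000 nM.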

Compound 3, half-maximal inhibitory concentration: 184000 nM
Compound 3: middle estimate off by 53-fold (1.72 log units), on the low side; measured number above the stated range.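

Hydroxy in place of hydrogen on an aromatic carbon is the first single change that can be read in this assay, and its step is large (a 97-fold higher number from compound 1 to compound 3 (1.99 log units; beyond the scatter)). This position, ortho to a fused ring, is therefore not a neutral site, although compound 1 alone could not show that. Compound 2 carries a limit, and compound 3 reads close to it: the limit of > 190000 nM in this assay, at which 1 of the 3 values shown sits.

On these data alone, it remains open whether the step belongs to hydroxy itself or would also follow from fluoro or an amine on the same carbon. Also open, as far as these compounds go, is whether hydroxy on another carbon of this ring gives a similar step.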